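The compounds below may be only part of what the source reports. "The series", "measured", "known", "first", "only" and "open" are said of these compounds alone.

Compound 2 `CN1CCN(c2ccc3c(c2)oc(=O)n3C(=O)NCCCCc2ccccc2)CC1` gives 116 nM in an assay on HEK293 cells for inhibition of acid ceramidase (Homo sapiens), read by fluorescence, with stated times of 10 min and 3 h; a higher number here means a weaker inhibitor, a lower number a stronger inhibitor. Of the three compounds with a number in this assay, compound 2 holds the second highest figure. Compound 1 `O=C(NCCCCc1ccccc1)n1c(=O)oc2cnccc21` reads 3 nM in this assay, a value lower than that of compound 2 by a gap beyond the scatter. Compound 3 `COCCCNC(=O)n1c(=O)oc2cc(-c3ccc(F)cc3)ccc21` reads 2600 nM in this assay, higher than compound 2 by a gap that is also beyond the scatter, though compound 2 lies closer to compound 3 than to compound 1.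

Compound 4 `CCN1CCC(c2ccc3c(c2)oc(=O)n3C(=O)NCCCCc2ccccc2)CC1` differs from compound 2 in one place: 1-ethylpiperidin-4-yl in place of 4-methylpiperazin-1-yl on an aromatic carbon. Everything else in the molecule is kept. For the measured compounds named here, no measured pair changes only this position, so there is no measured step against which the change can be set; both groups are six-membered non-aromatic rings carrying an alkyl on nitrogen, and the swap is counted as one ring heteroatom fewer and one heavy atom more. The expectation is therefore a step of a 1.2-fold lower number from compound 2 to compound 4 (0.06 log units; within the scatter) in this assay, within or only slightly beyond the scatter, in no firmly predictable direction. On that basis compound 4 is estimated at 100 nM in this assay, with a range from 30 nM to 400 nM.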

Compound 4, half-maximal inhibitory concentration: 92 nM
Compound 4: middle estimate off by 1.1-fold (0.04 log units), on the high side; the measured number falls inside the stated range.
By their numbers in this assay, from the lowest: compound 1; then compounds 4 and 2 (each within the scatter of the next); then compound 3.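

In this assay the exchange of 4-methylpiperazin-1-yl for 1-ethylpiperidin-4-yl gives a 1.3-fold lower number from compound 2 to compound 4 (0.10 log units; within the scatter) and is the only measured step at this position among the compounds shown. It shows that, on this aromatic carbon, a six-membered non-aromatic ring with 1 hetero atom can stand in for one with 2 hetero atoms, and that this pair cannot be told apart in this assay despite the loss of a hydrogen-bond acceptor and the gain of a heavy atom. Nothing measured here accounts for the two groups reading alike.

The swap alters the ring and the alkyl group on its nitrogen together, so the pair cannot show what each alteration does alone, and 1-methylpiperidin-4-yl would be needed to separate them. Both groups are also six-membered rings with an alkyl-bearing nitrogen, which leaves open how this position would respond to a quite different substituent, such as a carboxylic acid, a morpholine ring or a simple methoxy group.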